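The source may hold more compounds than are shown below. What is called first, only, known or untested is meant among the compounds shown, and "the series" means these compounds.

Measured compounds in a functional assay on MKN-74 cells (Homo sapiens) for antiproliferative activity, with a stated time of 24 h; a higher number here means a weaker inhibitor, a lower number a stronger inhibitor:
- compound 1, `NC(=O)c1c(NC(=O)c2ccccc2I)sc2c1CCN(C(=S)Nc1ccccc1Cl)C2`, gives 17500 nM
- compound 2, `NC(=O)c1c(NC(=O)c2ccccc2C(F)(F)F)sc2c1CCN(C(=S)Nc1ccccc1Cl)C2`, gives 21900 nM
- compound 3, `COc1ccccc1C(=O)Nc1sc2c(c1C(N)=O)CCN(C(=S)Nc1ccccc1Cl)C2`, gives 20500 nM

Compound 3 holds the second highest of the three numbers. Its nearest neighbour is compound 2, the step being a 1.1-fold lower number from compound 2 to compound 3 (0.03 log units; within the scatter); the step of a 1.2-fold higher number from compound 1 to compound 3 (0.07 log units; within the scatter) is equally small. All three values lie within the scatter of one another, so no ordering can be read from them.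

The next compound, compound 4, `NC(=O)c1c(NC(=O)c2ccncn2)sc2c1CCN(C(=S)Nc1ccccc1Cl)C2`, differs from compound 3 by pyrimidin-4-yl in place of 2-methoxyphenyl on a carbonyl carbon. The three measured steps all concern the substituent carried on the aromatic ring of the acyl group: a 1.3-fold higher number from compound 1 to compound 2 (0.10 log units; within the scatter), a 1.2-fold higher number from compound 1 to compound 3 (0.07 log units; within the scatter) and a 1.1-fold lower number from compound 2 to compound 3 (0.03 log units; within the scatter). None of them moves the number beyond the scatter, which points to this part of the molecule tolerating variation without a measurable effect. The change to compound 4 goes further, replacing the whole ring rather than one substituent on it, so the precedent is indirect and the uncertainty is wider; still, nothing in the series argues for a shift in either direction.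

Compound 4 is therefore expected near 22000 nM, with a range from 8000 nM to 60000 nM. The expected step, a 1.1-fold higher number from compound 3 to compound 4 (0.03 log units; within the scatter), stays within the scatter.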

Compound 4, half-maximal inhibitory concentration: 28400 nM
Compound 4: middle estimate off by 1.3-fold (0.11 log units), on the low side; the measured number falls inside the stated range.
By their numbers in this assay, from the lowest: compounds 1, 3, 2 and 4 (each within the scatter of the next).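

In this assay, the change at this carbonyl carbon now reaches the whole aromatic ring, not only one substituent on it, and the number still stays within the scatter for each replacement (for 2-methoxyphenyl a 1.4-fold higher number from compound 3 to compound 4 (0.14 log units; within the scatter); for 2-(trifluoromethyl)phenyl a 1.3-fold higher number from compound 2 to compound 4 (0.11 log units; within the scatter); for 2-iodophenyl a 1.6-fold higher number from compound 1 to compound 4 (0.21 log units; within the scatter)). The tolerance seen among the three substituted phenyl groups therefore extends, in these compounds, to pyrimidin-4-yl, a six-membered aromatic ring with 2 hetero atoms, so neither a carbon-only ring nor a substituent on the ring is shown to be required for a number of this size in this assay. No independent measurement bears on this result, so it stands as an observation without an explanation.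

The compounds shown leave open whether any group on this carbonyl carbon can move the number beyond the scatter, for instance a phenyl ring carrying an amine or a carboxylic acid, or a longer alkyl chain in place of the ring. From the compounds shown here alone, they also vary only at this one place, so the response to a change elsewhere on the shared core, such as a nitrile in place of the primary carboxamide, remains unknown.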